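The compounds below may be only part of what the source reports. "The series", "measured", "known", "first", "only" and "open" are said of these compounds alone.

Measured in a functional assay on HCT-116 cells (Homo sapiens), read by MTT assay, with a stated time of 72 h; a higher number here means a weaker inhibitor, a lower number a stronger inhibitor:
Compound 1 `Cc1ncnc2c1c(-c1ccsc1)cn2[C@@H]1O[C@H](CO)[C@@H](O)[C@H]1O`: 1430 nM
Compound 2 `Nc1nc(N)c2c(-c3ccsc3)cn([C@@H]3O[C@H](CO)[C@@H](O)[C@H]3O)c2n1`: > 20000 nM
Compound 3 `Nc1nc(N)c2c(-c3cc4ccccc4o3)cn([C@@H]3O[C@H](CO)[C@@H](O)[C@H]3O)c2n1`: 14000 nM

The figure for compound 2 is a limit and not a number. Compound 3 has the highest number among the exact values, beyond the scatter from compound 1. Compound 4 `Cc1nc(N)c2c(-c3cc4ccccc4o3)cn([C@@H]3O[C@H](CO)[C@@H](O)[C@H]3O)c2n1` differs from compound 3 by methyl in place of amino on an aromatic carbon, between two ring nitrogen atoms: methyl in place of amino on an aromatic carbon. Going by the values given here, no measured step makes this exchange. Among the compounds with values here, the one measured step, an at least 1.4-fold lower number from compound 2 to compound 3 (0.15 log units; that floor lies within the scatter), changes a different place and has a floor within the scatter, so it gives little guidance. Compound 1, which carries methyl and no amino group, gives 1430 nM, which weakly suggests a lower number. The expected step is a 2.8-fold lower number from compound 3 to compound 4 (0.45 log units; beyond the scatter), a modest move to a lower number. The estimate for compound 4 is 5000 nM, with an expected range of 1200 nM to 20000 nM.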

Compound 4, half-maximal inhibitory concentration: 13100 nM
Compound 4: the middle estimate sits 2.6-fold (0.42 log units) below what was measured; measured number inside the range.
By their numbers in this assay, from the lowest: compound 1; then compounds 4 and 3 (each within the scatter of the next). At a limit, above all of these: compound 2.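

In this assay, going by these compounds alone, the earlier compounds held no step at this carbon between two ring nitrogen atoms, and the first one shows that methyl in place of amino changes little (a 1.1-fold lower number from compound 3 to compound 4 (0.03 log units; within the scatter)). Amino, with its hydrogen-bond donor and acceptor, gives way to methyl, which has neither, and the number stays within the scatter in this pair. No measurement given here bears on why the number holds. Open, from the compounds shown here alone, are whether the exchange behaves alike with thiophen-3-yl on the core, and what methoxy or dimethylamino would do at this carbon.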